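Replacing chloro with amino: compound 3 to compound 4

The source may hold more compounds than are shown below. What is called first, only, known or untested is meant among the compounds shown, and "the series" means these compounds.

Values so far in a functional assay on Bel-7402 cells (Homo sapiens) for cytotoxicity, read by MTT assay, with a stated time of 48 h (a lower number here means a stronger inhibitor, a higher number a weaker inhibitor), are these:
- compound 1 `CCn1cc(-c2nc3ccccc3[nH]2)c(=O)c2cc(F)c(N3CCNCC3)nc21` gives 4100 nM
- compound 2 `CCn1cc(-c2nc3ccccc3o2)c(=O)c2cc(F)c(Cl)cc21` gives 28900 nM
- compound 3 `CCn1cc(-c2nc3ccc(Cl)cc3[nH]2)c(=O)c2cc(F)c(N3CCNCC3)nc21` gives 21500 nM

Among these three, compound 3 (21500 nM) lies within the scatter of compound 2 (28900 nM), and both numbers lie well above that of compound 1 (4100 nM). The next compound, compound 4 `CCn1cc(-c2nc3ccc(N)cc3[nH]2)c(=O)c2cc(F)c(N3CCNCC3)nc21`, has not yet been measured. It differs from compound 3 by one change, (amino in place of chloro on an aromatic carbon), with amino in place of chloro on an aromatic carbon. Going by the values given here, the one measured step that bears on this is a 5.2-fold higher number from compound 1 to compound 3 (0.72 log units; beyond the scatter), the step that adds the chloro group. That step is modest but beyond the scatter. Compound 2 differs from the others in more than one place and offers no clean comparison. Among the compounds with values here, no amino compound has been measured, and amino is not hydrogen, so the step is only a rough guide. A modest move towards a lower number is expected, smaller than the measured chloro step. The estimate amounts to a 2.4-fold lower number from compound 3 to compound 4 (0.38 log units; beyond the scatter) as the expected step. Compound 4 is expected at about 9000 nM in this assay, with an estimated range from 2500 nM to 30000 nM for its measurement.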

Compound 4, half-maximal inhibitory concentration: 93300 nM
Compound 4: middle estimate off by 10-fold (1.02 log units), on the low side, and the stated range ends below it.
By their numbers in this assay, from the lowest: compound 1; then compounds 3 and 2 (each within the scatter of the next); then compound 4.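

In this assay amino in place of chloro on this aromatic carbon brings a 4.3-fold higher number from compound 3 to compound 4 (0.64 log units; beyond the scatter) so the number moves further from that of the hydrogen compound rather than back towards it, and amino in place of hydrogen brings a 23-fold higher number from compound 1 to compound 4 (1.36 log units; beyond the scatter) which is larger than a 5.2-fold higher number from compound 1 to compound 3 (0.72 log units; beyond the scatter) seen with chloro. Among the three compounds that differ only in this place, hydrogen in compound 1 therefore has the lowest number, and both replacements, chloro with no hydrogen-bond donor or acceptor and amino with one of each, raise it, with none of the three going against this. Nothing shown here accounts for this shared direction or for the gap between chloro and amino.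

As far as these compounds go, it remains open whether any other group in this place, such as methyl, methoxy, fluoro or a carboxylic acid, would bring the number below that of compound 1. From the compounds shown here alone, it is also open whether the order of hydrogen, chloro and amino would hold on another aromatic carbon of this ring or with other parts of the core changed; compound 2 differs from the others in more than one place and cannot settle this.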